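Swapping the chlorophenyl for isopropyl on the piperidine amide

The source may report more compounds than this note shows. Statements on the series, on what has been measured and on what is new or still open speak of the compounds shown alone.

Measured so far:
- compound 1 `Cn1cncc1CN1CC(N(CC2CCN(C(=O)c3ccc(Cl)cc3)CC2)S(=O)(=O)c2ccccn2)Cc2cc(C#N)ccc21`: 0.5 10^-6 cm/s
- compound 2 `CC(=O)N1CCC(CN(C2Cc3cc(C#N)ccc3N(Cc3cncn3C)C2)S(=O)(=O)c2ccccn2)CC1`: 0.5 10^-6 cm/s

In an ADME assay on Caco-2 cells (Homo sapiens) for permeability, in the apical to basolateral direction (a lower number here means that the compound crosses the layer more slowly, a higher number that the compound crosses the layer faster), compound 1 gives 0.5 10^-6 cm/s, level with compound 2 at the digits shown, which gives 0.5 10^-6 cm/s. Compound 3 `CC(C)C(=O)N1CCC(CN(C2Cc3cc(C#N)ccc3N(Cc3cncn3C)C2)S(=O)(=O)c2ccccn2)CC1` has not been measured yet. It differs from compound 1 by isopropyl in place of 4-chlorophenyl on a carbonyl carbon. Among the compounds with values here, the one comparable step is no change at the digits printed from compound 1 to compound 2 (within the scatter), a change at the same carbonyl carbon, so no step beyond the scatter is expected in this assay either. Compound 3 is therefore estimated at 0.5 10^-6 cm/s, between 0.25 10^-6 cm/s and 1 10^-6 cm/s, an expected step of no change at the digits printed from compound 1 to compound 3 (within the scatter).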

Compound 3, apparent permeability: 0.5 10^-6 cm/s
For compound 3 middle estimate and measured number coincide at the digits printed; low and high end bracket the measured number.
By their numbers in this assay, from the lowest: compounds 1, 2 and 3 (each within the scatter of the next).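

In this assay, a third group on this carbonyl carbon gives the same picture: no change at the digits printed from compound 1 to compound 3 (within the scatter), and likewise no change at the digits printed from compound 2 to compound 3 (within the scatter). Isopropyl therefore joins 4-chlorophenyl and methyl as groups at this place that cannot be told apart in this read-out, and none of the three compounds goes against that. From the compounds shown here alone, whether a group carrying an amine or a carboxylic acid on this carbonyl carbon would give a different number remains open, as does the effect of changes elsewhere on the shared core. No measurement at hand offers an explanation for these matching values.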